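Phenyl to Cyclopentyl at the Triazole Side Chain

The source may report more compounds than this note shows. Statements on the series, on what has been measured and on what is new or still open speak of the compounds shown alone.

Three compounds have numbers in an assay on CHO cells for displacement of a labelled ligand from adenosine receptor A1 (Homo sapiens); a lower number here means a stronger inhibitor, a higher number a weaker inhibitor. Compound 1 `CNc1nc(-c2cn(Cc3cccc(OC)c3)nn2)nc2c1ncn2[C@@H]1O[C@H](CO)[C@@H](O)[C@H]1O` gives 957 nM, compound 2 `CNc1nc(-n2cc(-c3ccccn3)nn2)nc2c1ncn2[C@@H]1O[C@H](CO)[C@@H](O)[C@H]1O` gives 1970 nM, and compound 3 `CCNC(=O)[C@H]1O[C@@H](n2cnc3c(NC)nc(-n4cc(Cc5ccccc5)nn4)nc32)[C@H](O)[C@@H]1O` gives 510 nM. Compound 3 thus holds the lowest of the three numbers, though its gap to compound 1 lies within the scatter and only its gap to compound 2 lies beyond it. Compound 4 `CCNC(=O)[C@H]1O[C@@H](n2cnc3c(NC)nc(-n4cc(CC5CCCC5)nn4)nc32)[C@H](O)[C@@H]1O` differs from compound 3 by cyclopentyl in place of phenyl on a saturated chain carbon bound to an aromatic carbon, that is, benzyl to cyclopentylmethyl. Among the compounds with values here, no measured pair shows this change, so the expected step from compound 3 to compound 4 in this assay is a 1.2-fold higher number from compound 3 to compound 4 (0.07 log units; within the scatter), in no direction beyond the scatter. Compound 4 is therefore estimated at 600 nM, within a range from 200 nM to 1800 nM.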

Compound 4, inhibition constant: 1250 nM
Compound 4: middle estimate off by 2.1-fold (0.32 log units), on the low side; measured number inside the range.
By their numbers in this assay, from the lowest: compounds 3, 1, 4 and 2 (each within the scatter of the next, the first and the last beyond it).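

In this assay, cyclopentyl in place of phenyl on a saturated chain carbon bound to an aromatic carbon gives a 2.5-fold higher number from compound 3 to compound 4 (0.39 log units; beyond the scatter), so this place does respond to the ring it carries, though only modestly. The change swaps an aromatic ring for a non-aromatic one and also alters ring size, and this single pair cannot separate the two. No available evidence bears on why the number rises. From the compounds shown here alone, whether cyclohexyl at this place would stay close to compound 3 or to compound 4 remains open, as does the effect of an amine there.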